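Swapping the aryl group on the exocyclic double bond

The compounds below may be only part of what the source reports. "The series", "measured", "known", "first", "only" and "open" are said of these compounds alone.

Compound 2 `O=C1N=C(N2CCC[C@H]2C(=O)Nc2ccc3ncnc(Nc4cccc(Cl)c4)c3c2)S/C1=C/c1cccnc1Cl` carries a 2-chloropyridin-3-yl group on a double-bonded chain carbon bound to a double-bonded ring carbon. Among the compounds with values here, in a functional assay on A549 cells (Homo sapiens) for antiproliferative activity, read by MTT assay (a higher number here means a weaker inhibitor, a lower number a stronger inhibitor), compound 2 gives 10800 nM, the only actual number among the two results known so far. For compound 1 `O=C1N=C(N2CCC[C@H]2C(=O)Nc2ccc3ncnc(Nc4cccc(Cl)c4)c3c2)S/C1=C/c1cccc(Cl)c1`, which carries a 3-chlorophenyl group in the same place, the result in this assay is only a limit, > 50000 nM, not a number. Within the data shown here, the one measured step, an at least 4.6-fold lower number from compound 1 to compound 2 (0.66 log units; beyond the scatter), therefore rests on (the limit of > 50000 nM in this assay, at which 1 of the 2 values shown sits).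

Compound 3 `COc1ccccc1/C=C1/SC(N2CCC[C@H]2C(=O)Nc2ccc3ncnc(Nc4cccc(Cl)c4)c3c2)=NC1=O` differs from compound 2 by 2-methoxyphenyl in place of 2-chloropyridin-3-yl on a double-bonded chain carbon bound to a double-bonded ring carbon. This step returns to a ring of carbon only and replaces the chlorine with a methoxy group, so it resembles a partial reversal of the change that brought the gain from compound 1 to compound 2. On that basis the number is expected to move back up: from compound 2 to compound 3 an estimated 2.3-fold higher number from compound 2 to compound 3 (0.36 log units; beyond the scatter) in this assay. The expected value for compound 3 is 25000 nM, within a range of 8000 nM to 80000 nM, with a real chance that only a limit is reported.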

Compound 3, half-maximal inhibitory concentration: > 50000 nM
Compound 3: only a limit was reported (the forecaster's own chance of this, stated with the estimate: 40%); middle value at least 2.0-fold (0.30 log units) away from the limit.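

What the new step adds

In this assay this change gives an at least 4.6-fold higher number from compound 2 to compound 3 (0.66 log units; beyond the scatter), so the lower number seen for compound 2 does not carry over to every substituted aryl group at this place. As far as these compounds go, compound 3 gives > 50000 nM, which is a limit and not a number, so how far the step really reaches stays unknown. Two different carbon-only rings, 3-chlorophenyl in compound 1 and 2-methoxyphenyl in compound 3, now both end at a limit, 2-chloropyridin-3-yl alone gives an actual number, and the step between compound 1 and compound 3 cannot be read, which leaves any ranking of those two open: the limit of > 50000 nM in this assay, at which 2 of the 3 values shown sit.

The step from 2-chloropyridin-3-yl to 2-methoxyphenyl removes the ring nitrogen and exchanges the chlorine for a methoxy group at once, so the compounds shown cannot tell which of these changes goes with the shift in the number. From the compounds shown here alone, a 2-chlorophenyl group or a 2-methoxypyridin-3-yl group on the same carbon would separate the two, and whether a pyridine ring bearing an amine would go lower than compound 2 also remains open.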